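Amide-side variation on a shared triaryl imidazole core

The compounds below may be only part of what the source reports. "The series", "measured", "known", "first", "only" and "open" are said of these compounds alone.

Measured compounds:
compound 1 `Cn1c(-c2ccc(NC(=O)CCl)cc2)nc(-c2ccccc2)c1-c1ccccc1`, 28.7 ug/mL
compound 2 `Cn1c(-c2ccc(NC(=O)CSc3nc4ccccc4o3)cc2)nc(-c2ccccc2)c1-c1ccccc1`, 11 ug/mL
compound 3 `Cn1nnnc1SCC(=O)Nc1ccc(-c2nc(-c3ccccc3)c(-c3ccccc3)n2C)cc1`, 1.6 ug/mL

In a functional assay on HT-29 cells (Homo sapiens) for cytotoxicity, read by MTT assay, with a stated time of 24 h (on this read-out lower numbers stand for stronger inhibition and higher numbers for weaker inhibition), compound 3 gives the lowest number of the three measured compounds. Against compound 2 the step of a 6.9-fold lower number from compound 2 to compound 3 (0.84 log units; beyond the scatter) is modest, and against compound 1 the step of an 18-fold lower number from compound 1 to compound 3 (1.25 log units; beyond the scatter) is large, so compound 3 is the most potent here.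

Compound 4 `CN(C)/C=C/N1CCN(CC(=O)Nc2ccc(-c3nc(-c4ccccc4)c(-c4ccccc4)n3C)cc2)CC1` is not yet measured. Relative to compound 3 it carries 4-(2-(dimethylamino)ethenyl)piperazin-1-yl in place of (1-methyl-1H-tetrazol-5-yl)sulfanyl on a saturated chain carbon bound to a carbonyl carbon.

For the measured compounds named here, no measured step covers a change of this kind. What the three measured steps show is that the group on the saturated chain carbon bound to the carbonyl carbon matters: a 2.6-fold lower number from compound 1 to compound 2 (0.42 log units; beyond the scatter), an 18-fold lower number from compound 1 to compound 3 (1.25 log units; beyond the scatter) and a 6.9-fold lower number from compound 2 to compound 3 (0.84 log units; beyond the scatter) all lie beyond the scatter. Compound 4 loses the group that gave compound 3 its low number and gains one unlike anything measured, so a step back toward the numbers of compound 1 and compound 2 is expected, of uncertain size.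

The expected step is a 5.0-fold higher number from compound 3 to compound 4 (0.70 log units; beyond the scatter). Compound 4 is estimated at 8 ug/mL, with a range from 2 ug/mL to 30 ug/mL.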

Compound 4, half-maximal inhibitory concentration: 80 ug/mL
The estimate for compound 4 lay 10-fold (1.00 log units) below the measured number, and the stated range ends below it.
By their numbers in this assay, from the lowest: compound 3; then compound 2; then compound 1; then compound 4.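

In this assay, 4-(2-(dimethylamino)ethenyl)piperazin-1-yl on the saturated chain carbon bound to a carbonyl carbon gives a higher number against each earlier group: (1-methyl-1H-tetrazol-5-yl)sulfanyl (a 50-fold higher number from compound 3 to compound 4 (1.70 log units; beyond the scatter)), (1,3-benzoxazol-2-yl)sulfanyl (a 7.3-fold higher number from compound 2 to compound 4 (0.86 log units; beyond the scatter)) and chloro (a 2.8-fold higher number from compound 1 to compound 4 (0.45 log units; beyond the scatter)). The earlier compounds shown here showed only lower numbers when chloro was replaced, whereas this replacement goes the other way, so a change at this position can move the number in either direction, and compound 4 is the weakest of the four. No measurement at hand bears on the reason for this result.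

The compounds shown leave open whether the piperazin-1-yl ring or its 2-(dimethylamino)ethenyl substituent accounts for the change. An unsubstituted piperazin-1-yl or a morpholin-4-yl at the same place would separate the two.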